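The source may report more compounds than this note shows. Statements on the series, on what has been measured and on what is new or still open speak of the compounds shown alone.

Compounds measured so far:
compound 1 `Nc1nc(NCc2cccs2)nc2sc(-c3ccco3)nc12`: 6.43 nM
compound 2 `COc1cccc(CNc2nc(N)c3nc(-c4ccc(C)o4)sc3n2)c1`: 160 nM
compound 3 `COc1cccc(CNc2nc(N)c3nc(-c4cccs4)sc3n2)c1`: 430 nM

In an assay on CHO cells for displacement of a labelled ligand from adenosine receptor A3 (Homo sapiens), read by scintillation counting, with a stated time of 120 min (a higher number here means a weaker inhibitor, a lower number a stronger inhibitor), compound 3 gives the highest of the three numbers, and compound 2 the nearest to it. Within the data shown here, the one measured step, a 2.7-fold higher number from compound 2 to compound 3 (0.43 log units; beyond the scatter), concerns the aromatic group on the core, not the part changed here. Compound 4 `Nc1nc(NCc2cccs2)nc2sc(-c3cccs3)nc12` differs from compound 3 by thiophen-2-yl in place of 3-methoxyphenyl on a saturated chain carbon bound to a nitrogen on an aromatic ring. Among the measured compounds shown here, no measured step bears directly on this exchange; compound 1, which carries the same thiophen-2-ylmethyl group but a different aromatic group on the core, gives 6.43 nM, far lower than compound 3. A large drop is therefore expected, a 22-fold lower number from compound 3 to compound 4 (1.33 log units; beyond the scatter), though the scatter leaves its exact size open. Compound 4 is estimated at 20 nM, within 5 nM to 80 nM.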

Compound 4, inhibition constant: 38 nM
Compound 4: middle estimate off by 1.9-fold (0.28 log units), on the low side; low and high end bracket the measured number.
By their numbers in this assay, from the lowest: compound 1; then compound 4; then compound 2; then compound 3.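

In this assay, among these compounds, thiophen-2-yl in place of 3-methoxyphenyl on the saturated chain carbon gives an 11-fold lower number from compound 3 to compound 4 (1.05 log units; beyond the scatter) and is the first measured step at this position. With that group held constant, thiophen-2-yl in place of furan-2-yl on the core gives a 5.9-fold higher number from compound 1 to compound 4 (0.77 log units; beyond the scatter) and thus also shows that the core substituent matters in this series. No evidence given here accounts for either step. On these data alone, it remains open whether a cyclohexyl group or a longer chain ending in an aromatic ring would fit this position. As far as these compounds go, whether a furan-2-yl group there would match thiophen-2-yl also remains open.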